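A few compounds are considered here, and "the series" means these few. Any claim that something is new, unique, unknown or untested is made for them only; others in the source may bear on it.

The measured compounds:

Compound 1, `CNC(=N)Nc1nc(-c2ccc(OC)cc2)c(-c2ccc(OC)cc2)s1`: in a functional assay with Oryctolagus cuniculus as the target (on this read-out higher numbers stand for weaker inhibition and lower numbers for stronger inhibition), compound 1 gives 62 nM.
Compound 2, `C/N=C(/NC)Nc1nc(-c2ccc(OC)cc2)c(-c2ccc(OC)cc2)s1`: in this assay compound 2 gives 970 nM.
Compound 3, `COc1ccc(-c2nc(CN(C)C)sc2-c2ccc(OC)cc2)cc1`: in this assay compound 3 gives 96 nM.

Compound 3 stands second highest of the three numbers. Its nearest neighbour is compound 1, with a 1.5-fold higher number from compound 1 to compound 3 (0.19 log units; within the scatter), a gap that stays within the scatter; furthest from it is compound 2, with a 10-fold lower number from compound 2 to compound 3 (1.00 log units; beyond the scatter).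

Compound 4, `COc1ccc(-c2nc(C(=O)N(C)C)sc2-c2ccc(OC)cc2)cc1`, is the next step from compound 3: dimethylcarbamoyl in place of (dimethylamino)methyl on an aromatic carbon. The group sits on an aromatic carbon of the five-membered aromatic ring with one nitrogen and one sulfur, next to the ring nitrogen and next to the ring sulfur.

Going by the values given here, none of the measured steps exchanges this group for a dimethylcarbamoyl. The steps that touch the same aromatic carbon, a 1.5-fold higher number from compound 1 to compound 3 (0.19 log units; within the scatter) and a 10-fold lower number from compound 2 to compound 3 (1.00 log units; beyond the scatter), compare the (dimethylamino)methyl with guanidine-type groups, not with an amide. The shared core with its two 4-methoxyphenyl groups has so far held numbers within a narrow band except for compound 2. Among the compounds with values here, with no direct precedent, compound 4 is expected to stay near compound 3, with a 2.1-fold higher number from compound 3 to compound 4 (0.32 log units; beyond the scatter), a step not clearly beyond the scatter, and a wide range is therefore estimated for compound 4: 200 nM, from 50 nM to 1000 nM.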

Compound 4, half-maximal inhibitory concentration: < 100 nM
Compound 4 gave a limit, no number; the forecaster's own chance of this, stated with the estimate: 5%; middle value at least 2.0-fold (0.30 log units) away from the limit.
By their numbers in this assay, from the lowest: compounds 1 and 3 (each within the scatter of the next); then compound 2.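

In this assay compound 4 gives < 100 nM, which is a limit of the assay and not a number. Even so, the step of an at least 9.7-fold lower number from compound 2 to compound 4 (0.98 log units; beyond the scatter) shows that this aromatic carbon of the five-membered ring carries dimethylcarbamoyl without the number rising to that of compound 2, whereas the earlier compounds had shown this position only with (dimethylamino)methyl and guanidine-type groups. The steps from compound 3 to compound 4 and from compound 1 to compound 4 cannot be read, so the exchange of (dimethylamino)methyl for dimethylcarbamoyl has no measured size, and the reading rests on one value at that limit: the limit of < 100 nM in this assay, at which 1 of the 4 values shown sits.

The compounds shown leave open how far the true value of compound 4 lies from its limit, and so whether dimethylcarbamoyl differs at all from (dimethylamino)methyl at this position. They also leave open whether the two methyl groups on the amide nitrogen matter, which a primary amide or a carboxylic acid on the same aromatic carbon would address.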